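The source may hold more compounds than are shown below. What is called first, only, known or untested is meant among the compounds shown, and "the series" means these compounds.

Compound 3 `COc1cc(CC(O)c2ccc(-c3ccc(C)cc3)cc2)c([N+](=O)[O-])cc1OC` is the only one of the three measured compounds to give a number in an ADME assay on HeLa Rh cells (Homo sapiens) for cytotoxicity, read by microscopy; on this read-out lower numbers stand for higher toxicity in this test and higher numbers for lower toxicity in this test: compound 3 gives 4700 nM. For compound 1 `COc1cc(CC(O)c2ccc(-c3ccc(C=O)cc3)cc2)c([N+](=O)[O-])cc1OC` this assay reports only a limit, > 245000 nM. For compound 2 `COc1cc(CC(O)c2ccc(-c3ccc(CO)cc3)cc2)c([N+](=O)[O-])cc1OC` this assay likewise reports only a limit, > 244000 nM. Both measured steps that lead to compound 3 were large: an at least 52-fold lower number from compound 1 to compound 3 (1.71 log units; beyond the scatter) and an at least 51-fold lower number from compound 2 to compound 3 (1.71 log units; beyond the scatter). Compound 4 `COc1ccc(-c2ccc(C(O)Cc3cc(OC)c(OC)cc3[N+](=O)[O-])cc2)cc1` differs from compound 3 by methoxy in place of methyl on an aromatic carbon. For the measured compounds named here, no measured step swaps these two groups, so the expectation rests loosely on the two large steps, which both ran toward lower numbers when a formyl or a hydroxy was removed. For compound 4 a small step toward a higher number, near the scatter, is expected, a 1.7-fold higher number from compound 3 to compound 4 (0.23 log units; within the scatter). Compound 4 is estimated at 8000 nM, between 2500 nM and 30000 nM.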

Compound 4, half-maximal cytotoxic concentration: > 244000 nM
Compound 4 was reported as a limit; the forecaster's own chance of this, stated with the estimate: 15%; at least 30-fold (1.48 log units) between middle value and limit.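

In this assay, for the compounds shown here, methoxy in place of methyl, para to a large group, gives an at least 51-fold higher number from compound 3 to compound 4 (1.71 log units; beyond the scatter), so the first direct swap at this position shows that even this small change can matter greatly. Methyl is now the only one of the four groups here that comes with a number, and the steps from compound 1 and compound 2 to compound 4 cannot be read, as both ends are limits. Compound 4 is reported only as a limit: the limit of > 244000 nM in this assay, at which 2 of the 4 values shown sit.

Going by these compounds, how far compound 4 lies past that limit stays open. So does whether an ethyl, an amine or a carboxylic acid at this position would give a number like compound 3 or a limit like compound 4.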